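The source may report more compounds than this note shows. Statements on the series, on what has been measured and on what is new or still open speak of the compounds shown alone.

Among the measured compounds shown here, in a functional assay on MKN-45 cells (Homo sapiens) for inhibition, read by CCK-8 assay, with a stated time of 24 h (on this read-out lower numbers stand for stronger inhibition and higher numbers for weaker inhibition), compound 1 (`Cc1cccc(-n2cc(-c3ccc(/C=C4\C(=O)Nc5ccc(F)cc54)cc3)nn2)c1`) gives 6810 nM as its half-maximal inhibitory concentration, the lower of the two numbers available so far. Compound 2 (`O=C1Nc2ccc(F)cc2C1=Cc1ccc(-c2cn(-c3ccc(Cl)cc3)nn2)cc1`) gives 15800 nM in this assay and so stands higher, by a gap beyond the usual scatter. Compound 1 is therefore the stronger inhibitor of this pair. Compound 3 (`O=C1Nc2ccc(F)cc2/C1=C/c1ccc(-c2cn(-c3ccc(Cl)c(C(F)(F)F)c3)nn2)cc1`) has yet to be measured. It carries 4-chloro-3-(trifluoromethyl)phenyl in place of 3-methylphenyl on an aromatic nitrogen of the five-membered aromatic ring with 3 nitrogen, a change counted as 4-chloro-3-(trifluoromethyl)phenyl in place of 3-methylphenyl on an aromatic nitrogen in the comparison with compound 1.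

For the measured compounds named here, no measured pair here isolates a single change, so the data offer no direct guide to this swap. With compound 2 at 15800 nM as the only other point, no step beyond the scatter is expected in this assay and there is only a slight lean toward a higher number, meaning weaker inhibition. The expected change is a 1.3-fold higher number from compound 1 to compound 3 (0.12 log units; within the scatter) and it remains an estimate. For compound 3 the estimated value is 9000 nM with an expected range from 2800 nM to 28000 nM until the measurement arrives.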

Compound 3, half-maximal inhibitory concentration: > 20000 nM
Compound 3 ended at the assay's limit; the forecaster's own chance of this, stated with the estimate: 5%; at least 2.2-fold (0.34 log units) between middle value and limit.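

In this assay, among the compounds shown here, putting 4-chloro-3-(trifluoromethyl)phenyl in place of 3-methylphenyl on the aromatic nitrogen of the five-membered aromatic ring gives an at least 2.9-fold higher number from compound 1 to compound 3 (0.46 log units; beyond the scatter), which is the first step at this position that isolates one change, and it runs toward weaker inhibition. The reading for compound 3, > 20000 nM, is a limit of the assay and not a number: the limit of > 20000 nM in this assay, at which 1 of the 3 values shown sits. The step therefore shows that inhibition in these cells depends on which phenyl group sits on this nitrogen, even though the groups that leave and enter have the same counts of hydrogen-bond donors and acceptors, but it fixes only a minimum size for the loss.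

The compounds shown do not settle how much of this step belongs to the chlorine and how much to the trifluoromethyl, and they give no cause for it. Going by these compounds, it also remains open how a phenyl group carrying an amine or a carboxylic acid, or a longer alkyl chain in place of the phenyl group, would read in this assay.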